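Swapping cyclopentyl for isopropyl: a half-life question

The source may hold more compounds than are shown below. What is called first, only, known or untested is meant among the compounds shown, and "the series" means these compounds.

Within the data shown here, in an ADME assay on microsomes (Rattus norvegicus) for metabolic stability (on this read-out higher numbers stand for a longer-lived compound and lower numbers for a shorter-lived compound), compound 1 (`O=C(C1CCCC1)N1N=CCC1c1ccccc1`) gives 0.2 h and holds the higher of the two numbers measured so far. Compound 2 (`Cc1ccc(C2CC=NN2C(=O)C(C)(C)C)cc1F`) gives 0.0433 h and so sits lower by a gap beyond the scatter. Yet compound 2 differs from compound 1 in more than one place, and the gap cannot be tied to any single group.

Compound 3 (`CC(C)C(=O)N1N=CCC1c1ccccc1`) has not been measured yet. It carries isopropyl in place of cyclopentyl on a carbonyl carbon and keeps the rest of compound 1 unchanged. Among the measured compounds shown here, no measured pair in this assay shows what a single change of this kind does. The expectation therefore leans on compound 1 at 0.2 h as the closest reference, and no shift beyond the scatter is expected in either direction. The expected change is small (a 1.2-fold lower number from compound 1 to compound 3 (0.07 log units; within the scatter)) and stays within the scatter. For compound 3 the estimated half-life is 0.17 h with an expected range of 0.07 h to 0.4 h in this measurement.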

Compound 3, half-life: 1.33 h
Beside the measured number, compound 3's estimate is 7.8-fold (0.89 log units) below it; measured number above the stated range.
By their numbers in this assay, from the lowest: compound 2; then compound 1; then compound 3.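

In this assay, putting isopropyl in place of cyclopentyl on a carbonyl carbon gives a 6.7-fold higher number from compound 1 to compound 3 (0.82 log units; beyond the scatter), so a single change at this position, with the rest of the structure kept, moves the half-life beyond the scatter. The two earlier compounds differ in more than one place and could not isolate this position, whereas this pair ties the shift to the group on the carbonyl carbon, with the higher number going to the open-chain group. The change takes away one five-membered non-aromatic ring of carbon only and reduces the group from 5 heavy atoms to 3, but nothing measured here explains why the half-life rises.

The compounds shown leave open whether the rise follows the loss of the ring or the smaller heavy-atom count, a question that a cyclobutyl group or a straight propyl chain on the same carbonyl carbon could help separate. They also leave open whether the same swap gives a step of similar size on a core other than that of compound 1.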